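The compounds below may be only part of what the source reports. "The series", "measured", "known", "first", "only" and "open" are said of these compounds alone.

Three compounds sharing one core were read in a functional assay on microsomes from liver (Rattus norvegicus, strain Wistar) for inhibition, read by spectrophotometry, with a stated time of 60 min; on this read-out lower numbers stand for stronger inhibition and higher numbers for weaker inhibition: compound 1 `COc1ccc(C(=O)ON=C2CC(c3ccc(O)c(OC)c3)N(C)C(c3ccc(O)c(OC)c3)C2)cc1` gives 40000 nM, compound 2 `COc1cc(C2CC(=NOC(=O)c3ccc(Cl)cc3)CC(c3ccc(O)c(OC)c3)N2C)ccc1O` gives 121000 nM, and compound 3 `COc1cc(C2CC(=NOC(=O)c3ccc(O)cc3)CC(c3ccc(O)c(OC)c3)N2C)ccc1O` gives 22500 nM. The measured steps are a 1.8-fold lower number from compound 1 to compound 3 (0.25 log units; within the scatter), a 5.4-fold lower number from compound 2 to compound 3 (0.73 log units; beyond the scatter) and a 3.0-fold higher number from compound 1 to compound 2 (0.48 log units; beyond the scatter), so compound 3 stands level with compound 1 and clear of compound 2. Compound 4 `COc1cc(C2CC(=NO)CC(c3ccc(O)c(OC)c3)N2C)ccc1O` differs from compound 3 as follows: hydrogen in place of (4-hydroxyphenyl)carbonyl on an oxygen. All three measured steps alter one group on the ring that compound 4 loses, and none removes that ring, so they bear on this change only loosely. Going by the values given here, no step clearly beyond the scatter is therefore expected, and the estimated step is a 1.6-fold higher number from compound 3 to compound 4 (0.19 log units; within the scatter). For compound 4 the expected value is 35000 nM, with an estimated range of 12000 nM to 100000 nM.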

Compound 4, half-maximal inhibitory concentration: 167000 nM
The estimate for compound 4 lay 4.8-fold (0.68 log units) below the measured number, and the stated range ends below it.
By their numbers in this assay, from the lowest: compounds 3 and 1 (each within the scatter of the next); then compounds 2 and 4 (each within the scatter of the next).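

In this assay, replacing the (4-hydroxyphenyl)carbonyl on the oxygen with hydrogen gives a 7.4-fold higher number from compound 3 to compound 4 (0.87 log units; beyond the scatter), so the intact ring-bearing ester weighs on inhibition in a way the substituent swaps could not show. Removing the (4-methoxyphenyl)carbonyl likewise gives a 4.2-fold higher number from compound 1 to compound 4 (0.62 log units; beyond the scatter). Removing the (4-chlorophenyl)carbonyl gives only a 1.4-fold higher number from compound 2 to compound 4 (0.14 log units; within the scatter), so the cost of removal depends on the group that ring carries.

From the compounds shown here alone, whether a small acetyl group or a plain methyl on that oxygen would behave like these esters stays open. Nothing measured here explains these steps.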